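A few compounds are considered here, and "the series" means these few. Any claim that something is new, unique, unknown or untested is made for them only; others in the source may bear on it.

Compound 1 `Cc1ccc(Oc2ccc(/C=N/n3c(C)nc4ccccc4c3=O)cc2)cc1`, compound 2 `CCCc1nc2ccccc2c(=O)n1/N=C/c1ccc(Oc2ccc(Br)cc2)cc1` and compound 3 `Cc1nc2ccccc2c(=O)n1/N=C/c1ccc(Oc2ccc3ccccc3c2)cc1` share one core and differ in the group on the oxygen and in the chain on the core. In a physicochemical assay for lipophilicity, in phosphate buffer, measured as octanol-water partition (a lower number here means a more polar compound, a higher number a more lipophilic compound), compound 1 gives 4.32, compound 2 gives 5.88 and compound 3 gives 5.22, so compound 3 stands second highest of the three, below compound 2 and above compound 1. Going by the values given here, the one single-point step measured so far, a number 0.90 log units higher from compound 1 to compound 3 (beyond the scatter), concerns the group on the oxygen. Compound 4 `CCCc1nc2ccccc2c(=O)n1/N=C/c1ccc(Oc2ccc3ccccc3c2)cc1` differs from compound 3 by ethyl in place of hydrogen on a saturated chain carbon bound to an aromatic carbon. Among the compounds with values here, no measured step isolates this chain change; compounds 1 and 2 differ in two places at once. Still, an upward step is expected for compound 4, a number 0.98 log units higher from compound 3 to compound 4 (beyond the scatter), giving an estimated 6.2 within 5.7 to 6.7.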

Compound 4, partition coefficient: 6.12
Compound 4: middle estimate off by 0.08 log units, on the high side, within the range that was stated.
By their numbers in this assay, from the lowest: compound 1; then compound 3; then compounds 2 and 4 (each within the scatter of the next).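

In this assay, ethyl in place of hydrogen on a saturated chain carbon bound to an aromatic carbon now stands alone as a change: it gives a number 0.90 log units higher from compound 3 to compound 4 (beyond the scatter) with nothing else differing. With the same chain on the core, a change of the group on the oxygen alone gives a number 0.24 log units higher from compound 2 to compound 4 (within the scatter) and so leaves the two groups unseparated in this read-out. Nothing measured here explains either step. On these data alone, whether a longer chain such as butyl, or an amine at the end of the chain, would extend or reverse the rise stays open. So does the size of the ethyl step with 4-bromophenyl on the oxygen.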